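The source may report more compounds than this note shows. Statements on the series, on what has been measured and on what is new or still open speak of the compounds shown alone.

Measured compounds:
- compound 1 `O=C(CN1CCC(c2cccc[n+]2[O-])CC1)Nc1ccc(F)cc1F`: 103 nM
- compound 2 `COc1cccc(C)c1NC(=O)CN1CCC(c2cccc[n+]2[O-])CC1`: 340 nM

Both were tested in a functional assay on HEK293 cells for agonist activity at D(4) dopamine receptor (Homo sapiens), read by FLIPR; a lower number here means that less compound is needed, a higher number that more compound is needed for the effect. Compound 1 gives the lower of the two numbers; compound 2 sits higher, and that gap lies beyond the scatter of repeat measurements. Compound 3 `Cc1ccc(Cl)cc1NC(=O)CN1CCC(c2cccc[n+]2[O-])CC1` has not yet been measured. It differs from compound 1 in one place: 5-chloro-2-methylphenyl in place of 2,4-difluorophenyl on an amide-type nitrogen. Going by the values given here, with no measured pair showing this exact change, only a small step is expected, if any, perhaps slightly toward a higher number, as a 1.7-fold higher number from compound 1 to compound 3 (0.24 log units; within the scatter). Compound 3 is therefore estimated at 180 nM, within a range from 60 nM to 550 nM.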

Compound 3, half-maximal effective concentration: 126 nM
Compound 3: the middle estimate sits 1.4-fold (0.15 log units) above what was measured, within the range that was stated.
By their numbers in this assay, from the lowest: compounds 1 and 3 (each within the scatter of the next); then compound 2.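

Putting 5-chloro-2-methylphenyl in place of 2,4-difluorophenyl on the amide-type nitrogen gives a 1.2-fold higher number from compound 1 to compound 3 (0.09 log units; within the scatter) and so leaves compound 1 and compound 3 indistinguishable in this measurement. This place therefore accepts a ring carrying chlorine and methyl as readily as one carrying two fluorines, at least for this pair. No measured evidence is available to explain this match.

Still open, going by these compounds, is whether the same place would accept a different kind of group, such as a carboxylic acid or an amine, instead of these substituted phenyl rings.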